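The compounds below may be only part of what the source reports. "The series", "measured", "known", "first", "only" and "open" are said of these compounds alone.

Working notes on the series. Compound 1 `Cc1cc(C)nc(SCc2cc(=O)c3cc(Cl)ccc3o2)n1` and compound 2 `Cc1nnc(SCc2cc(=O)c3cc(Cl)ccc3o2)o1` share a chloro group on the core; how the two cores differ beyond that is not broken down here. In a functional assay on SW480 cells (Homo sapiens) for cytotoxicity, read by MTT assay, with a stated time of 72 h (a higher number here means a weaker inhibitor, a lower number a stronger inhibitor), compound 1 gives only a limit of the assay, > 25000 nM. In this assay compound 2 likewise gives only a limit, > 25000 nM. Compound 3 `Cc1nnc(SCc2cc(=O)c3ccccc3o2)o1` carries the change (hydrogen in place of chloro on an aromatic carbon); in this assay compound 3 again gives only a limit, > 25000 nM, so the step that the two limits leave unreadable from compound 2 to compound 3 cannot be sized, given that (the limit of > 25000 nM in this assay, at which 3 of the 3 values shown sit).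

Compound 4 `Cc1cc(C)nc(SCc2cc(=O)c3ccccc3o2)n1` carries the same change on compound 1, (hydrogen in place of chloro on an aromatic carbon). The step from compound 1 to compound 4 is expected to be a step that the limit leaves unreadable from compound 1 to compound 4, resting on compound 1 at > 25000 nM and on the unreadable step that the two limits leave unreadable from compound 2 to compound 3. Compound 4 is estimated at 40000 nM, between 20000 nM and 150000 nM, most likely reported again as a limit.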

Compound 4, half-maximal inhibitory concentration: > 25000 nM
Compound 4: no number, only a limit (the forecaster's own chance of this, stated with the estimate: 85%); the middle value does not contradict the limit.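

The step between compound 1 and compound 4 cannot be read, since both give only a limit: the limit of > 25000 nM in this assay, at which 4 of the 4 values shown sit.

The compounds shown leave open how large the step for hydrogen in place of chloro is in this assay, on either core.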